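The source may hold more compounds than are shown below. What is called first, only, known or untested is meant among the compounds shown, and "the series" means these compounds.

Compound 1 (`O=C1c2ccccc2C(=O)N1c1ccccc1`) is the reference point for this step, but in a functional assay on HONE1 cells (Homo sapiens) for cytotoxicity, read by MTT assay, with a stated time of 24 h (a higher number here means a weaker inhibitor, a lower number a stronger inhibitor), compound 1 has no number to start from, with its entry reading "not determined" (no result reported). Compound 2 (`O=C1c2ccccc2C(=O)N1c1cccc([N+](=O)[O-])c1`) offers no help, as compound 2 is also recorded as "not determined" (no result reported). Within the data shown here, the only reading comes from compound 3 (`N#Cc1ccccc1N1C(=O)c2ccccc2C1=O`). Compound 3 gives > 200000 nM, which is a limit of the assay and not a number.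

The compound now in question is compound 4 (`O=C1c2ccccc2C(=O)N1c1ccc(S)cc1`). The structural change is sulfanyl in place of hydrogen on an aromatic carbon, para to a large group. Among the measured compounds shown here, no measured pair in this set shows what such a change does, so the size of the step in this assay is a judgement rather than a reading. A modest step towards stronger inhibition is expected, meaning a lower number, though a result reported only as a limit would be no surprise. For the measured compounds named here, the one guide for this expectation is compound 3, with its limit of > 200000 nM. Compound 4 is expected to come in near 120000 nM, with an estimated range of 30000 nM to 300000 nM.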

Compound 4, half-maximal inhibitory concentration: > 200000 nM
Compound 4: no number, only a limit (the forecaster's own chance of this, stated with the estimate: 55%); middle value at least 1.6-fold (0.22 log units) from the limit.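

In this assay compound 4 gives > 200000 nM, which is a limit of the assay and not a number. Compound 1 has no number to compare with, so no step can be read between compound 1 and compound 4. The compounds shown leave open whether sulfanyl in place of hydrogen changes the result in this assay at all.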